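This account rests on a few compounds, and the source may have more. Where it says the series, first, only, none or still open, it means among the compounds named here.

Two compounds share the same core and differ only in the groups on the ring attached to the carbonyl. Compound 1 `O=C(/C=C/c1ccc2c(c1)B(O)OC2)c1ccc(OCc2ccccc2)cc1` carries a benzyloxy group on that ring, and in an ADME assay on L929 cells (Mus musculus) for cytotoxicity, read by resazurin assay, with a stated time of 72 h (on this read-out higher numbers stand for weaker inhibition and lower numbers for stronger inhibition), compound 1 gives > 10 ug/mL, which is a limit of the assay rather than a measured number (the limit of > 10 ug/mL in this assay, at which 1 of the 2 values shown sits). Compound 2 `COc1ccc(C(=O)/C=C/c2ccc3c(c2)B(O)OC3)c(OC)c1` carries two methoxy groups instead, and in this assay compound 2 gives 7.87 ug/mL. Compound 1 therefore stands at the limit, where one of the two values shown sits.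

Compound 3 `O=C(/C=C/c1ccc2c(c1)B(O)OC2)c1ccc(-c2ccccc2)cc1` has not yet been measured. It differs from compound 1 in a single place: phenyl in place of benzyloxy on an aromatic carbon. Among the compounds with values here, no measured pair shows a change of this kind, so there is no measured step to lean on. The step of a number no higher from compound 1 to compound 3 (the limit leaves the size open) is expected to stay within the usual scatter, with no clear direction. Compound 3 is expected to give about 10 ug/mL, within a range from 4 ug/mL to 25 ug/mL.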

Compound 3, half-maximal inhibitory concentration: > 10 ug/mL
Compound 3 was reported as a limit (the forecaster's own chance of this, stated with the estimate: 45%); the middle value sits exactly at the limit.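

Within the data shown here, compound 1 and compound 3 both end at a limit of the assay rather than a measured number, so no step between them can be read: the limit of > 10 ug/mL in this assay, at which 2 of the 3 values shown sit. As far as these compounds go, whether phenyl in place of benzyloxy shifts the value in this assay at all, and by how much, stays open.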